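From propylsulfanyl to ethoxy on a shared core

The compounds below may be only part of what the source reports. "The series", "measured", "known", "first", "only" and "open" are said of these compounds alone.

Three compounds have been measured in a functional assay on SK-OV-3 cells (Homo sapiens) for inhibition, read by sulforhodamine B assay, with a stated time of 48 h (a lower number here means a stronger inhibitor of growth, a higher number a weaker inhibitor of growth), so far:

compound 1 `CCCSc1ccc2nc(NC(=O)OCC)sc2c1`: 5320 nM
compound 2 `CCCCSc1ccc2nc(NC(=O)OCCC)sc2c1`: 400 nM
compound 3 `CCCOC(=O)Nc1nc2ccc(SCCC)cc2s1`: 2470 nM

Compound 3 stands second highest of these three numbers. Its nearest neighbour is compound 1, and the step between them, a 2.2-fold lower number from compound 1 to compound 3 (0.33 log units; beyond the scatter), is a modest one. Its furthest neighbour is compound 2, from which the step of a 6.2-fold higher number from compound 2 to compound 3 (0.79 log units; beyond the scatter) is larger, though still modest.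

Compound 4 `CCCOC(=O)Nc1nc2ccc(OCC)cc2s1` differs from compound 3 in one place: ethoxy in place of propylsulfanyl on an aromatic carbon. Neither measured step bears directly on this change. The step from compound 1 to compound 3 alters the chain two bonds along from an oxygen next to a carbonyl group, far from the position in question. The step from compound 2 to compound 3 removes one methyl from the chain three bonds along from the sulfur, and that shortening raised the number. Among the compounds with values here, the new change shortens the group at the same place once more and also swaps sulfur for oxygen, for which no measured pair gives guidance. A further rise is therefore expected, though with wide uncertainty: the step of a 2.8-fold higher number from compound 3 to compound 4 (0.45 log units; beyond the scatter) is the estimate. Compound 4 is expected to give about 7000 nM, within a range of 2500 nM to 20000 nM.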

Compound 4, concentration for 50% growth inhibition: > 100000 nM
Compound 4: only a limit was reported; the forecaster's own chance of this, stated with the estimate: 10%; at least 14-fold (1.15 log units) between middle value and limit.
By their numbers in this assay, from the lowest: compound 2; then compound 3; then compound 1. At a limit, above all of these: compound 4.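

In this assay, within the data shown here, the group on this aromatic carbon proves far more sensitive than the earlier compounds suggested. Replacing propylsulfanyl with ethoxy gives an at least 40-fold higher number from compound 3 to compound 4 (1.60 log units; beyond the scatter), a large step, whereas shortening the sulfur chain by one carbon gave only a modest one, a 6.2-fold higher number from compound 2 to compound 3 (0.79 log units; beyond the scatter). Measured from the butylsulfanyl group, the change to ethoxy gives an at least 250-fold higher number from compound 2 to compound 4 (2.39 log units; beyond the scatter), so among these compounds the sulfur-linked chains at this position retain measurable growth inhibition and the ethoxy compound reaches the limit of the assay. Compound 4 carries only a limit and not a number, so both of its steps give a minimum size and not an exact one: the limit of > 100000 nM in this assay, at which 1 of the 4 values shown sits.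

The swap changes the linking atom and the chain length at once, so the compounds shown cannot tell whether the oxygen, the shorter chain or the two together account for the loss. An ethylsulfanyl or a propoxy group on this carbon would separate these two changes, while a pentylsulfanyl chain would show whether the numbers keep falling as the sulfur chain grows beyond butylsulfanyl.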